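Ring-nitrogen substituent series: from aryl back to acyl

The source may report more compounds than this note shows. Statements on the series, on what has been measured and on what is new or still open speak of the compounds shown alone.

The shared core carries a six-membered non-aromatic ring with two nitrogens, and its amine nitrogen holds the variable group. In a functional assay on cells (T-cell, Homo sapiens) for inhibition (on this read-out lower numbers stand for stronger inhibition and higher numbers for weaker inhibition), compound 1 `COc1ccc(-c2cnc3nc(N)nc(N4CCN(C(=O)NCc5ccc(F)cc5)CC4)c3n2)cc1OC` gives 37 nM; compound 2 `COc1ccc(-c2cnc3nc(N)nc(N4CCN(C(=O)COc5ccccc5)CC4)c3n2)cc1OC` gives 4 nM; compound 3 `COc1ccc(-c2cnc3nc(N)nc(N4CCN(c5ccc(C)cc5)CC4)c3n2)cc1OC` gives 300 nM, the highest of the three numbers. The relevant steps are an 8.1-fold higher number from compound 1 to compound 3 (0.91 log units; beyond the scatter) and a 75-fold higher number from compound 2 to compound 3 (1.88 log units; beyond the scatter), so compound 3, which bears 4-methylphenyl, sits well above both carbonyl-bearing analogues. Compound 4 `COc1ccc(-c2cnc3nc(N)nc(N4CCN(C(=O)c5ccccc5)CC4)c3n2)cc1OC` differs from compound 3 by benzoyl in place of 4-methylphenyl on an amine nitrogen in a ring. This puts a carbonyl back on the ring nitrogen, reversing the direction of the two measured steps, so a lowered number beyond the scatter is expected, a 25-fold lower number from compound 3 to compound 4 (1.40 log units; beyond the scatter). Compound 4 is estimated at 12 nM, range 3 nM to 50 nM.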

Compound 4, half-maximal inhibitory concentration: 400 nM
Compound 4: middle estimate off by 33-fold (1.52 log units), on the low side; the whole stated range lies below it.
By their numbers in this assay, from the lowest: compound 2; then compound 1; then compounds 3 and 4 (each within the scatter of the next).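

In this assay, with a 1.3-fold higher number from compound 3 to compound 4 (0.12 log units; within the scatter) as the step, benzoyl and 4-methylphenyl cannot be told apart, so a carbonyl on the amine nitrogen in a ring does not by itself give the low numbers. The group on the carbonyl carbon carries the difference, with a 100-fold higher number from compound 2 to compound 4 (2.00 log units; beyond the scatter) for phenyl against phenoxymethyl and an 11-fold higher number from compound 1 to compound 4 (1.03 log units; beyond the scatter) for phenyl against (4-fluorobenzyl)amino. The data offer no explanation for these steps.

Open, from the compounds shown here alone, is whether phenylacetyl, lacking the ether oxygen of phenoxymethyl, keeps the number of compound 2 or moves toward that of compound 4.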